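A Dimethylamino Group Enters the Core of Compound 1

A few compounds are considered here, and "the series" means these few. Any claim that something is new, unique, unknown or untested is made for them only; others in the source may bear on it.

compound 1 `CC(CC(C)(C)C)Oc1cccc2cccnc12`: > 2000 nM
compound 2 `CCC(C)COc1cccc2ccc(N)nc12`: 36 nM

In an assay on cells with melanin-concentrating hormone receptor 1 (Homo sapiens) as the target, read by radioligand binding (on this read-out lower numbers stand for stronger inhibition and higher numbers for weaker inhibition), compound 1 gives > 2000 nM, which is a limit of the assay rather than a number (the limit of > 2000 nM in this assay, at which 1 of the 2 values shown sits). Compound 2 gives 36 nM in this assay. Compound 3 `CC(CC(C)(C)C)Oc1cccc2ccc(N(C)C)nc12` differs from compound 1 by dimethylamino in place of hydrogen on an aromatic carbon. Among the measured compounds shown here, no step between measured compounds is known, so the size of this change is open; a gain beyond the scatter is expected, estimated as an at least 13-fold lower number from compound 1 to compound 3 (1.12 log units; beyond the scatter). Compound 3 is expected to reach 150 nM, between 30 nM and 800 nM, because compound 2 gives 36 nM.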

Compound 3, half-maximal inhibitory concentration: > 2000 nM
Compound 3 gave a limit, no number (the forecaster's own chance of this, stated with the estimate: 15%); at least 13-fold (1.12 log units) between middle value and limit.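

Compound 1 and compound 3 both stand at a limit of the assay, not at a number, so no step can be read between them: the limit of > 2000 nM in this assay, at which 2 of the 3 values shown sit.

The compounds shown leave open what dimethylamino in place of hydrogen on an aromatic carbon does to the read-out.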